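The source may report more compounds than this note shows. Statements on the series, on what has been measured and on what is new or still open speak of the compounds shown alone.

Of the compounds shown here, three built on one shared core have been tested in an assay on microsomes from liver for inhibition of 3-hydroxy-3-methylglutaryl-coenzyme A reductase (Rattus norvegicus); a lower number here means a stronger inhibitor, a higher number a weaker inhibitor. Compound 1 `O=C(O)C[C@H](O)C[C@H](O)CCn1c(C(F)(F)F)nc(-c2ccccc2)c1-c1ccc(F)cc1` gives 31 nM. Compound 2 `Cc1cccc(-c2nc(C(F)(F)F)n(CC[C@@H](O)C[C@@H](O)CC(=O)O)c2-c2ccc(F)cc2)c1` gives 29 nM, and compound 3 `O=C(O)C[C@H](O)C[C@H](O)CCn1c(C(F)(F)F)nc(-c2ccc(F)cc2)c1-c1ccc(F)cc1` gives 38 nM. On these numbers compound 3 stands at the upper end, but neither separation exceeds the usual scatter: a 1.2-fold higher number from compound 1 to compound 3 (0.09 log units; within the scatter), and a 1.3-fold higher number from compound 2 to compound 3 (0.12 log units; within the scatter).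

Compound 4 `Cc1ccc(-c2nc(C(F)(F)F)n(CC[C@@H](O)C[C@@H](O)CC(=O)O)c2-c2ccc(F)cc2)cc1` has not yet been measured. Its difference from compound 3 is methyl in place of fluoro on an aromatic carbon. Among the measured compounds shown here, three measured steps bear on it. Fluoro entering this ring gave a 1.2-fold higher number from compound 1 to compound 3 (0.09 log units; within the scatter); methyl entering the same ring, at another carbon, gave a 1.1-fold lower number from compound 1 to compound 2 (0.03 log units; within the scatter); and the exchange of the whole aryl group gave a 1.3-fold higher number from compound 2 to compound 3 (0.12 log units; within the scatter). Every substitution on this ring so far has left the number where it was, and nothing among these compounds suggests that methyl in place of fluoro should behave otherwise.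

Compound 4 is therefore expected to show no step beyond the scatter, a 1.2-fold lower number from compound 3 to compound 4 (0.06 log units; within the scatter). The estimate for compound 4 in this assay is 33 nM, with a range of 15 nM to 70 nM.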

Compound 4, half-maximal inhibitory concentration: 43 nM
Estimate against measurement, compound 4: 1.3-fold (0.11 log units) below, within the range that was stated.
By their numbers in this assay, from the lowest: compounds 2, 1, 3 and 4 (each within the scatter of the next).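

In this assay, the carbon para to a large group now carries methyl as well as fluoro, and exchanging one for the other stays within the scatter (a 1.1-fold higher number from compound 3 to compound 4 (0.05 log units; within the scatter)). Methyl at this carbon also stays within the scatter of hydrogen (a 1.4-fold higher number from compound 1 to compound 4 (0.14 log units; within the scatter)), and 4-methylphenyl in place of 3-methylphenyl does the same (a 1.5-fold higher number from compound 2 to compound 4 (0.17 log units; within the scatter)), so among these four compounds neither the identity of the substituent nor the placing of the methyl separates one compound from another. Nothing shown gives a measured reason for this flat response.

From the compounds shown here alone, all the substituents seen at this carbon are hydrogen or groups of one heavy atom, so it remains open whether the number would also hold with an amine, a carboxylic acid or a longer chain such as butyl in the same place. The compounds shown also leave open whether the 4-fluorophenyl group on the neighbouring part of the shared core would tolerate exchange as readily, since that group is the same in all four.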